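This account rests on a few compounds, and the source may have more. Where it says the series, first, only, none or still open, it means among the compounds named here.

Measured so far:
Compound 1 `C=C(Br)C(=O)Nc1cccc(-c2cn3nc(-c4ccc(F)cc4)sc3n2)c1`, giving 830 nM in a functional assay on CCRF-CEM cells (Homo sapiens) for inhibition, read by cell counting, with a stated time of 3 days; on this read-out lower numbers stand for stronger inhibition and higher numbers for weaker inhibition
Compound 2 `C=C(Br)C(=O)Nc1cccc(-c2cn3nc(-c4cccs4)sc3n2)c1`, giving 410 nM in this assay

Among these two numbers compound 2 stands lowest in this assay; the only neighbour is compound 1, and the step of a 2.0-fold lower number from compound 1 to compound 2 (0.31 log units; beyond the scatter) places compound 2 at the stronger end, though by a modest margin. Compound 3 `C=C(Br)C(=O)Nc1cccc(-c2cn3nc(-c4ccc(OC)cc4)sc3n2)c1` has not yet been measured. It differs from compound 2 in one place: 4-methoxyphenyl in place of thiophen-2-yl on an aromatic carbon. Among the measured compounds shown here, the one measured step that touches the same position is the exchange of the aryl group on the shared core, a 2.0-fold lower number from compound 1 to compound 2 (0.31 log units; beyond the scatter), where a six-membered carbon ring gave way to a five-membered ring. Compound 3 carries a six-membered carbon ring again, now with a methoxy group in place of the fluorine of compound 1, so the closest guide is the value of compound 1, 830 nM. On that basis a move back toward a higher number is expected in this assay, though a step no larger than the scatter would not be surprising. Compound 3 is therefore estimated at 650 nM, with a range from 250 nM to 1700 nM, which would mean a step of a 1.6-fold higher number from compound 2 to compound 3 (0.20 log units; within the scatter).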

Compound 3, half-maximal inhibitory concentration: 1200 nM
Compound 3: the middle estimate sits 1.8-fold (0.27 log units) below what was measured; low and high end bracket the measured number.
By their numbers in this assay, from the lowest: compound 2; then compounds 1 and 3 (each within the scatter of the next).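

In this assay, 4-methoxyphenyl in place of thiophen-2-yl gives a 2.9-fold higher number from compound 2 to compound 3 (0.47 log units; beyond the scatter), so the second aryl exchange at this position of the shared core points the same way as the first: compound 2, with its five-membered ring, gives the lowest number, and neither of the two compounds with a six-membered ring goes against this. Methoxy in place of fluoro, a change on the six-membered ring itself, gives a 1.4-fold higher number from compound 1 to compound 3 (0.16 log units; within the scatter), so the two groups at that ring's 4-position cannot be told apart here, and among these three compounds the choice of ring counts for more than the choice between these two groups on it. Nothing shown here explains why the groups rank this way.

Among the compounds shown here, with only one five-membered ring in the set, it remains open whether the lower number of compound 2 belongs to five-membered rings in general or to thiophen-2-yl in particular, a question that furan-2-yl, with oxygen in place of sulfur, would help to answer. Also open, as far as these compounds go, is how a plain phenyl ring, or a phenyl ring carrying an amine or a carboxylic acid, would compare at this position.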